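The source may hold more compounds than are shown below. What is called first, only, known or untested is meant among the compounds shown, and "the series" means these compounds.

Of the compounds shown here, two sharing one core have been measured for how strongly they slow the growth of a breast-cancer cell line. Compound 1, with the structure `COc1ccc(CN(C(=O)Nc2ccc(F)c(Cl)c2)n2cnnc2)cc1OC`, gives in a functional assay on MCF7 cells (Homo sapiens) for cytotoxicity, read by MTT assay, with a stated time of 48 h (on this read-out higher numbers stand for weaker inhibition and lower numbers for stronger inhibition), a value of 30100 nM. Compound 2, with the structure `COc1ccc(CN(C(=O)Nc2ccc(C)cc2)n2cnnc2)cc1OC`, carries a 4-methylphenyl in place of the 3-chloro-4-fluorophenyl on the amide-type nitrogen. In this assay compound 2 reaches only the limit of the measurement, > 50000 nM, so no number is known for it; this is described by the limit of > 50000 nM in this assay, at which 1 of the 2 values shown sits. The step of an at least 1.6-fold higher number from compound 1 to compound 2 (0.22 log units; that floor lies within the scatter) therefore reads as a floor, not a fixed size.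

Compound 3, with the structure `COc1cc(CN(C(=O)Nc2ccc(C)cc2)n2cnnc2)cc(OC)c1OC`, differs from compound 2 by a single change: methoxy in place of hydrogen on an aromatic carbon. Within the data shown here, no measured step touches this part of the molecule, so the one known step gives no guidance on its size or direction. Because compound 2 already stands at > 50000 nM, the starting point is the weakest the measurement can report. Compound 3 is estimated at 60000 nM, within the range 25000 nM to 150000 nM. That estimate implies a step that the limit leaves unreadable from compound 2 to compound 3, a change expected to stay within the scatter, most likely with the limit reported again.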

Compound 3, half-maximal inhibitory concentration: > 50000 nM
Compound 3 gave a limit, no number; the forecaster's own chance of this, stated with the estimate: 65%; the middle value does not contradict the limit.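

Among these compounds, compound 3, like compound 2, gives a limit rather than a number in this assay, so no step from compound 2 to compound 3 can be read: the limit of > 50000 nM in this assay, at which 2 of the 3 values shown sit.

The compounds shown leave open how strongly compound 2 and compound 3 really act, and whether methoxy in place of hydrogen on an aromatic carbon changes that at all.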